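Swapping Chloro for Fluoro in a Small Series

The compounds below may be only part of what the source reports. "The series", "measured", "known", "first", "only" and "open" are said of these compounds alone.

For the measured compounds named here, in a functional assay on A549 cells (Homo sapiens) for antiproliferative activity, read by MTT assay, with a stated time of 48 h (on this read-out lower numbers stand for stronger inhibition and higher numbers for weaker inhibition), three related compounds have numbers so far. Compound 1 `Cc1ccc(-c2cc(NC(=O)/C=C/c3ccc(Cl)cc3)n[nH]2)cc1` gives 1490 nM in this test, compound 2 `O=C(/C=C/c1ccc(Cl)cc1)Nc1cc(-c2ccccc2)[nH]n1` gives 1390 nM and compound 3 `O=C(/C=C\c1ccc(C(F)(F)F)cc1)Nc1cc(-c2ccccc2)[nH]n1` gives 880 nM under the same conditions. These values all lie within the usual scatter of one another, so compound 1 does not stand apart from the other two, and no ranking among them can be trusted.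

Compound 4 `Cc1ccc(-c2cc(NC(=O)/C=C/c3ccc(F)cc3)n[nH]2)cc1` is still unmeasured. It differs from compound 1 by a single exchange (fluoro in place of chloro on an aromatic carbon) with fluoro in place of chloro on an aromatic carbon, so that 4-chlorophenyl becomes 4-fluorophenyl.

Going by the values given here, no measured pair makes this same exchange. Among the compounds with values here, the only single-place comparison is a different one, hydrogen in place of methyl on an aromatic carbon, and it gave a 1.1-fold lower number from compound 1 to compound 2 (0.03 log units; within the scatter) as its whole effect, which stays within the scatter. Within the data shown here, compound 3 differs from compound 1 in more than one place and offers no clean step.

On this thin evidence, no shift beyond the scatter is expected in this assay and neither direction is favoured. The estimated change is a 1.0-fold higher number from compound 1 to compound 4 (0.00 log units; within the scatter) and thus too small to read. For compound 4 the estimated value is 1500 nM with an expected range from 750 nM to 3000 nM once it is tested.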

Compound 4, half-maximal inhibitory concentration: 1250 nM
Beside the measured number, compound 4's estimate is 1.2-fold (0.08 log units) above it, within the range that was stated.
By their numbers in this assay, from the lowest: compounds 3, 4, 2 and 1 (each within the scatter of the next).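

In this assay the exchange of chloro for fluoro gives a 1.2-fold lower number from compound 1 to compound 4 (0.08 log units; within the scatter) and so does not separate the two compounds. For the compounds shown here, this is the first direct reading at this place, on an aromatic carbon para to a large group, as the only clean step available earlier concerned the methyl group elsewhere in the molecule; within this one pair, 4-chlorophenyl and 4-fluorophenyl cannot be told apart by this test. No accompanying measurement offers an explanation of this result.

On these data alone, both groups exchanged here are single halogen atoms with no hydrogen-bond donors or acceptors, so the result says nothing about how a group of another kind would behave at the same place, such as an amine, a carboxylic acid or a methoxy group, and whether any of these would produce a step beyond the scatter remains open. As far as these compounds go, it also rests on one pair, so whether the same exchange would give a similarly small step on the core of compound 2, which lacks the methyl group, is still unknown.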